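Ether series notes: aryl swap on the benzyl ether

The source may report more compounds than this note shows. Statements on the series, on what has been measured and on what is new or still open speak of the compounds shown alone.

Compound 1 `Cc1nn(-c2ncnc3nc[nH]c23)c2c1C(OCc1ccc(C(C)C)cc1)CC(=O)N2` is the reference point here. Going by the values given here, in a functional assay on HEK293 cells for agonist activity at G-protein coupled receptor 39 (Homo sapiens), read by scintillation proximity assay and inositol phosphate accumulation, with a stated time of 75 min (a higher number here means that more compound is needed for the effect, a lower number that less compound is needed), compound 1 gives 1690 nM, the highest of the two numbers measured so far in the set. Compound 2 `CCC(C(=O)NC1CC(=O)Nc2c1c(C)nn2-c1ncnc2nc[nH]c12)c1ccccc1` differs from compound 1 at several positions; in this assay compound 2 gives 79 nM, and the gap from compound 1 to compound 2 lies beyond the usual scatter. Compound 3 `Cc1cc(C)nc(-n2nc(C)c3c2NC(=O)CC3c2ccc(F)cc2F)n1` is reported in this assay only as a limit, > 10000 nM, so no number can be put beside it; this is the limit of > 10000 nM in this assay, at which 1 of the 3 values shown sits, case.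

Compound 4 `Cc1nn(-c2ncnc3nc[nH]c23)c2c1C(OCc1ccccc1F)CC(=O)N2` has not yet been measured in this assay. Relative to compound 1 the change is 2-fluorophenyl in place of 4-isopropylphenyl on a saturated chain carbon bound to an oxygen on a saturated carbon. Among the compounds with values here, no pair of measured compounds differs only at this position, so the size of the step has to be guessed rather than read. The expectation is a modest weakening, possibly within the scatter, with a real chance that the result comes back as a limit rather than a number. Compound 4 is estimated at 3500 nM, with a likely range from 900 nM to 12000 nM. The expected step from compound 1 to compound 4 is a 2.1-fold higher number from compound 1 to compound 4 (0.32 log units; beyond the scatter).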

Compound 4, half-maximal effective concentration: 78 nM
Beside the measured number, compound 4's estimate is 45-fold (1.65 log units) above it; the whole stated range lies above it.
By their numbers in this assay, from the lowest: compounds 4 and 2 (each within the scatter of the next); then compound 1. At a limit, above all of these: compound 3.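

Swapping the aryl group on the benzyl ether turns out to be a strong lever at this position, which the earlier compounds could not show, since no two of them differ in one place only. In this assay, 2-fluorophenyl in place of 4-isopropylphenyl on the saturated chain carbon bound to the oxygen gives a 22-fold lower number from compound 1 to compound 4 (1.34 log units; beyond the scatter), so on the core of compound 1 the 4-isopropylphenyl group, with its 9 heavy atoms, is not required here, and 2-fluorophenyl, with 7 heavy atoms, serves far better. Going by these compounds alone, nothing measured so far bears on why this step is so large.

The step combines two changes, the loss of the isopropyl group and the arrival of the fluorine, so their shares cannot be told apart; a plain benzyl or a 2-chlorobenzyl group on the same oxygen would begin to separate them. Also open, on these data alone, is how this position responds to an amine or a carboxylic acid on the aryl ring, or to a longer chain between the oxygen and the ring.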